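Compound 3 to compound 4: one group exchanged

A few compounds are considered here, and "the series" means these few. Any claim that something is new, unique, unknown or untested is made for them only; others in the source may bear on it.

Three related compounds have been measured in a functional assay (blood) for inhibition, with Homo sapiens as the target; a higher number here means a weaker inhibitor, a lower number a stronger inhibitor. Compound 1 `COC(C)c1cc(-c2ccccc2)c2ccc(OCc3cccc(C4(O)CCOCC4)c3)cc2c1` gives > 1000 nM, which is a limit of the assay and not a number. Compound 2 `N#Cc1cc(-c2ccoc2)c2ccc(OCc3cccc(C4(O)CCOCC4)c3)cc2c1` gives 10 nM. Compound 3 `CC1(C)COC(c2cc(-c3ccoc3)c3ccc(OCc4cccc(C5(O)CCOCC5)c4)cc3c2)=N1` gives 2900 nM, the higher of the two values that are numbers.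

Compound 4 `OC1(c2cccc(COc3ccc4c(-c5ccoc5)cc(Cc5nccs5)cc4c3)c2)CCOCC1` is still unmeasured. The exchange is a group of 6 heavy atoms (4 carbon, 1 nitrogen, 1 sulfur; one five-membered aromatic ring with 2 hetero atoms) in place of a group of 7 heavy atoms (5 carbon, 1 nitrogen, 1 oxygen; one five-membered non-aromatic ring with 2 hetero atoms), on an aromatic carbon. The entering (1,3-thiazol-2-yl)methyl group stays on the same aromatic carbon, meta to a furan-3-yl group.

Going by the values given here, only one measured step bears on this carbon: a 290-fold higher number from compound 2 to compound 3 (2.46 log units; beyond the scatter), which is large and beyond the scatter. It shows that the read-out in this assay responds strongly to the group placed here. The new group is not the nitrile of compound 2 at 10 nM, so only a partial return towards that value is expected. This estimate amounts to a 9.7-fold lower number from compound 3 to compound 4 (0.99 log units; beyond the scatter), a moderate step to a lower number. Compound 4 is expected at 300 nM, with an estimated range of 40 nM to 2500 nM.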

Compound 4, half-maximal inhibitory concentration: 660 nM
Compound 4: the middle estimate sits 2.2-fold (0.34 log units) below what was measured; the range from low to high includes it.
By their numbers in this assay, from the lowest: compound 2; then compound 4; then compound 3.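

On this aromatic carbon, with the furan-3-yl group kept, the read-out in this assay separates two ring-bearing groups: a 4.4-fold lower number from compound 3 to compound 4 (0.64 log units; beyond the scatter) shows that (1,3-thiazol-2-yl)methyl gives a clearly lower number than the non-aromatic ring of compound 3, so a ring on this carbon does not by itself fix the read-out at the level of compound 3. Even so, a 66-fold higher number from compound 2 to compound 4 (1.82 log units; beyond the scatter) keeps the nitrile of compound 2 well ahead, and both ring-bearing groups remain far from it. No measurement shown explains the difference between these groups.

The compounds shown leave open whether the thiazole ring or its methyl link matters more. They also leave open how a smaller group such as an amine, or a carboxylic acid, would read on this carbon.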